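Swapping the ring on the amide nitrogen of a thiazolidinedione

The source may report more compounds than this note shows. Statements on the series, on what has been measured and on what is new or still open speak of the compounds shown alone.

Two compounds share a core and differ only in the ring attached to an amide-type nitrogen. Compound 1 `O=C(COc1ccc2cc(/C=C3/SC(=O)NC3=O)ccc2c1)Nc1ccccc1` gives 2100 nM in an assay on isolated protein for inhibition of histone deacetylase 4 (Homo sapiens), with a stated time of 1 h; a higher number here means a weaker inhibitor, a lower number a stronger inhibitor. Compound 2 `Cc1cc(NC(=O)COc2ccc3cc(/C=C4/SC(=O)NC4=O)ccc3c2)no1` gives 1700 nM in this assay. The step of a 1.2-fold lower number from compound 1 to compound 2 (0.09 log units; within the scatter) shows that these two numbers cannot be told apart, so compound 2 stands level with compound 1 rather than ahead of it.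

Compound 3 `O=C(COc1ccc2cc(/C=C3/SC(=O)NC3=O)ccc2c1)Nc1ccc(Br)c(Br)c1` carries the change (3,4-dibromophenyl in place of 5-methyl-1,2-oxazol-3-yl on an amide-type nitrogen). Among the compounds with values here, the only measured step that bears on a ring swap at this position is a 1.2-fold lower number from compound 1 to compound 2 (0.09 log units; within the scatter), which stayed within the scatter, so exchanging one flat ring for another at this nitrogen has so far barely moved the number. On that basis compound 3 is expected to show a step of a 1.1-fold lower number from compound 2 to compound 3 (0.03 log units; within the scatter), with no clear direction beyond the scatter. The estimate for compound 3 in this assay is 1600 nM, with a likely range from 600 nM to 4500 nM.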

Compound 3, half-maximal inhibitory concentration: 4900 nM
For compound 3 the middle estimate is 3.1-fold (0.49 log units) below the measured one; the whole stated range lies below it.
By their numbers in this assay, from the lowest: compounds 2 and 1 (each within the scatter of the next); then compound 3.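

Unlike the earlier swap at this amide-type nitrogen, this change produces a measurable shift in this assay: the 3,4-dibromophenyl group gives a 2.9-fold higher number from compound 2 to compound 3 (0.46 log units; beyond the scatter) and a 2.3-fold higher number from compound 1 to compound 3 (0.37 log units; beyond the scatter). Both steps are modest but beyond the scatter, so compound 3 is the weakest inhibitor of the three. The second step is the simpler comparison, since the two rings differ only by the two bromine atoms, and it shows that this position does not accept every aromatic ring equally.

From the compounds shown here alone, it remains open whether a single bromine would produce a similar shift, or how a phenyl ring carrying chlorine, fluorine, an amine or a carboxylic acid would compare. Nothing available here explains why the dibrominated ring gives the higher number.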